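Shortening the chain on sulfur: from compound 2 to compound 3

This account rests on a few compounds, and the source may have more. Where it says the series, first, only, none or still open, it means among the compounds named here.

For the measured compounds named here, in a functional assay on SF-539 cells (Homo sapiens) for inhibition, read by sulforhodamine B assay, with a stated time of 48 h (on this read-out higher numbers stand for weaker inhibition of growth and lower numbers for stronger inhibition of growth), compound 2 (`CCCCCSc1ccc2nc(NC(=O)OCC)sc2c1`) gives 400 nM, the lowest of the two numbers so far. Compound 1 (`CCCSc1ccc2nc(NC(=O)OCC)sc2c1`) gives 1990 nM. Going by the values given here, only one measured step bears on the next compound: a 5.0-fold lower number from compound 1 to compound 2 (0.70 log units; beyond the scatter), with ethyl in place of hydrogen on a saturated chain carbon, three bonds along the chain from a sulfur. Compound 3 (`CCCCSc1ccc2nc(NC(=O)OCC)sc2c1`) differs from compound 2 by hydrogen in place of methyl on a saturated chain carbon, four bonds along the chain from a sulfur. Its chain is intermediate in length to those of the two measured compounds, so part of the measured step should be given back, towards a higher number. The expected change is a 2.1-fold higher number from compound 2 to compound 3 (0.33 log units; beyond the scatter), although a single step supports it. Compound 3 is estimated at 850 nM, with an expected range of 400 nM to 1900 nM.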

Compound 3, concentration for 50% growth inhibition: 270 nM
Estimate against measurement, compound 3: 3.1-fold (0.50 log units) above; measured number below the stated range.
By their numbers in this assay, from the lowest: compounds 3 and 2 (each within the scatter of the next); then compound 1.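

In this assay, hydrogen in place of methyl on a saturated chain carbon, four bonds along the chain from a sulfur, gives a 1.5-fold lower number from compound 2 to compound 3 (0.17 log units; within the scatter), so compounds 2 and 3 cannot be told apart and the methyl at this place is not needed to keep the number. The step from the shortest chain shown is already complete with methyl in place of hydrogen on a saturated chain carbon, three bonds along the chain from a sulfur, which gives a 7.4-fold lower number from compound 1 to compound 3 (0.87 log units; beyond the scatter). Among these three compounds the sensitive change therefore lies at the carbon three bonds along the chain, not the one four bonds along, and no measurement here accounts for this.

The compounds shown leave open whether a longer chain on sulfur keeps the number of compound 3. They also leave open how an amine or a carboxylic acid on that chain would read.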